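Methyl on the sulfonyl ring: a repeated change

The source may report more compounds than this note shows. Statements on the series, on what has been measured and on what is new or still open speak of the compounds shown alone.

Measured compounds:
compound 1 `O=C1/C(=C/c2cccnc2)CN(S(=O)(=O)c2ccccc2)C/C1=C\c1ccccc1F` — 8210 nM in a functional assay on HepG2 cells (Homo sapiens) for cytotoxicity, read by MTT assay, with a stated time of 24 h; a higher number here means a weaker inhibitor, a lower number a stronger inhibitor
compound 2 `Cc1ccc(S(=O)(=O)N2C/C(=C\c3cccnc3)C(=O)/C(=C/c3ccccc3F)C2)cc1` — 4200 nM in this assay
compound 3 `O=C1/C(=C/c2cccnc2)CN(S(=O)(=O)c2ccccc2)C/C1=C\c1ccccc1C(F)(F)F` — 5370 nM in this assay

Of the compounds shown here, three share a core and have been tested in this assay. Compound 2 differs from compound 1 by methyl in place of hydrogen on an aromatic carbon. That change gave a 2.0-fold lower number from compound 1 to compound 2 (0.29 log units; within the scatter). Compound 3 differs from compound 1 by trifluoromethyl in place of fluoro on an aromatic carbon, and that change gave a 1.5-fold lower number from compound 1 to compound 3 (0.18 log units; within the scatter). Compound 3 stands close to compound 2 in this assay, and both steps among the measured compounds lie within the scatter, so no order among the three can be stated.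

Compound 4, `Cc1ccc(S(=O)(=O)N2C/C(=C\c3cccnc3)C(=O)/C(=C/c3ccccc3C(F)(F)F)C2)cc1`, has not yet been measured. It differs from compound 3 by methyl in place of hydrogen on an aromatic carbon. This is the same change that was made from compound 1 to compound 2, here on the core of compound 3 rather than that of compound 1; the two cores differ by trifluoromethyl in place of fluoro on an aromatic carbon as described above. The place of the change is described in the same words in both cases.

Among the compounds with values here, the expectation for compound 4 rests on the single earlier instance of this change: because a 2.0-fold lower number from compound 1 to compound 2 (0.29 log units; within the scatter) was observed, a step of similar size is expected from compound 3 to compound 4 in this assay, namely a 1.9-fold lower number from compound 3 to compound 4 (0.28 log units; within the scatter). Since that earlier step was itself within the scatter, the estimate carries a wide range. Compound 4 is therefore estimated at 2800 nM in this assay, with a range from 1400 nM to 6500 nM.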

Compound 4, half-maximal inhibitory concentration: 2930 nM
Beside the measured number, compound 4's estimate is 1.0-fold (0.02 log units) below it; low and high end bracket the measured number.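

In this assay, methyl in place of hydrogen on the aromatic carbon of the phenylsulfonyl group gave a 1.8-fold lower number from compound 3 to compound 4 (0.26 log units; within the scatter), and this matches the earlier instance of the change on the core of compound 1: the same change on two cores in this assay, a 2.0-fold lower number (0.29 log units; within the scatter) from compound 1 to compound 2 and a 1.8-fold lower number (0.26 log units; within the scatter) from compound 3 to compound 4, 1.1-fold (0.03 log units) apart, within the scatter of two such steps. The trifluoromethyl change read the other way round gave a 1.4-fold lower number from compound 2 to compound 4 (0.16 log units; within the scatter), and it too matches its earlier instance, so the two changes carried from one core to the other with no sign that either depends on the group changed by the other: the same change on two cores in this assay, a 1.5-fold lower number (0.18 log units; within the scatter) from compound 1 to compound 3 and a 1.4-fold lower number (0.16 log units; within the scatter) from compound 2 to compound 4, 1.1-fold (0.03 log units) apart, within the scatter of two such steps. Within the data shown here, this shows agreement on only two cores and in only one assay, and since each of these steps lies within the scatter, it does not show that either change truly moves the number, nor does it establish any order among the compounds joined by these steps.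

The compounds shown leave open whether a larger difference would appear with an amine, a carboxylic acid or a longer chain such as ethyl in place of the methyl of the 4-methylphenyl group. They also leave open whether the same agreement would hold on a core carrying some other group in place of fluoro or trifluoromethyl.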